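Swapping the aniline headgroup in a pyrimidinyl urea series

The source may hold more compounds than are shown below. What is called first, only, known or untested is meant among the compounds shown, and "the series" means these compounds.

Measured so far:
compound 1, `COc1cc(NC(=O)Nc2cc(Nc3ccc(F)c(Cl)c3)ncn2)cc(OC)c1`: 77.5%
compound 2, `COc1ccc(Br)cc1Nc1cc(NC(=O)Nc2c(Cl)cccc2Cl)ncn1`: 69%
compound 3, `COc1ccc(C(F)(F)F)cc1Nc1cc(NC(=O)Nc2c(Cl)cccc2Cl)ncn1`: 89%

In a functional assay on PC-9 cells (Homo sapiens) for inhibition, read by MTT assay, with a stated time of 48 h, tested at 10 uM (on this read-out higher numbers stand for more inhibition at the one concentration tested (going by the name of the read-out) and lower numbers for less inhibition), compound 1 stands second of three; its gap to compound 2 lies within the scatter, while compound 3 sits beyond it. Compound 4, `COc1cc(NC(=O)Nc2cc(Nc3cc(I)ccc3OC)ncn2)cc(OC)c1`, differs from compound 1 by 5-iodo-2-methoxyphenyl in place of 3-chloro-4-fluorophenyl on a nitrogen on an aromatic ring. Among the compounds with values here, the only measured step, a number 20 percentage points higher from compound 2 to compound 3 (beyond the scatter), alters a different group on a different urea end, so it does not bear directly on this change. Compounds 2 and 3 do show that anilines carrying a methoxy and a halogen keep activity in the same range. Compound 4 is therefore expected to stay close to compound 1, with a number 0.5 percentage points higher from compound 1 to compound 4 (within the scatter) as the estimated step. The estimate for compound 4 is 78%, between 60% and 92%.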

Compound 4, a percentage reported as inhibition, at one concentration (the size of the read-out at that concentration, not a potency): 91%
Compound 4: the middle estimate sits 13 percentage points below what was measured, within the range that was stated.
By their numbers in this assay, from the lowest: compounds 2 and 1 (each within the scatter of the next); then compounds 3 and 4 (each within the scatter of the next).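

In this assay, putting 5-iodo-2-methoxyphenyl in place of 3-chloro-4-fluorophenyl on the nitrogen gives a number 13.5 percentage points higher from compound 1 to compound 4 (beyond the scatter). This is the first step shown at this position with the rest of the molecule held fixed, and it shows that the choice of aromatic group there can change the read-out beyond the usual scatter. No data shown here explain this gain. Going by these compounds, it remains open whether the methoxy, the iodo or both together carry the step, and how a phenyl group bearing an amine or a carboxylic acid would behave at this position.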